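A Methyl Added to the Fused Ring of Compound 3

The source may report more compounds than this note shows. Statements on the series, on what has been measured and on what is new or still open speak of the compounds shown alone.

Of the compounds shown here, three have been measured in a functional assay on WIL2 cells (Homo sapiens) for inhibition; on this read-out lower numbers stand for stronger inhibition and higher numbers for weaker inhibition. Compound 1 `C#CCN(Cc1ccc2nc(C)nc(O)c2c1)c1ccc(C(=O)N[C@@H](CC(C)C(=O)O)C(=O)N[C@@H](CCC(=O)O)C(=O)O)cc1` gives 500 nM, and compound 2 `C#CCN(Cc1ccc2nc(C)nc(O)c2c1)c1ccc(C(=O)N[C@@H](CCC(=O)O)C(=O)N(C)CC(=O)O)cc1` gives 330 nM. Compound 3 `Cc1nc(O)c2cc(CN(C)c3ccc(C(=O)N[C@@H](CCC(=O)O)C(=O)N(C)[C@@H](CCC(=O)O)C(=O)O)c(F)c3)ccc2n1` gives 2300 nM, the highest of the three numbers; its gap to compound 1 is beyond the usual scatter, and its gap to compound 2, the furthest, is wider still. Compound 4 `Cc1nc(O)c2cc(CN(C)c3ccc(C(=O)N[C@@H](CCC(=O)O)C(=O)N(C)[C@@H](CCC(=O)O)C(=O)O)c(F)c3)c(C)cc2n1` differs from compound 3 in a single place: methyl in place of hydrogen on an aromatic carbon. Within the data shown here, no measured pair shows what such a change does here. The step from compound 3 to compound 4 is expected to be small, a 1.2-fold lower number from compound 3 to compound 4 (0.06 log units; within the scatter), with no change beyond the scatter in either direction. For compound 4 the estimate in this assay is 2000 nM, within a range from 800 nM to 5000 nM.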

Compound 4, half-maximal inhibitory concentration: 630 nM
Beside the measured number, compound 4's estimate is 3.2-fold (0.50 log units) above it; measured number outside the range, below it.
By their numbers in this assay, from the lowest: compounds 2, 1 and 4 (each within the scatter of the next); then compound 3.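

Methyl in place of hydrogen on this aromatic carbon, ortho to a large group, moves the read-out: in this assay the change gives a 3.7-fold lower number from compound 3 to compound 4 (0.56 log units; beyond the scatter). Among these compounds, this is the first step that isolates a single place, and it shows that this position responds to one added carbon, in the direction of stronger inhibition. No available data bear on why the number falls. The compounds shown leave open whether an ethyl, a chlorine or a methoxy on the same carbon would do the same. They also leave open whether methyl here would give a similar step on the core of compound 1 or compound 2.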